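Aryl swap on the aromatic nitrogen of the shared core

The source may hold more compounds than are shown below. What is called first, only, known or untested is meant among the compounds shown, and "the series" means these compounds.

Measured in a functional assay on HCT-116 cells (Homo sapiens) for antiproliferative activity, read by MTT assay, with a stated time of 48 h; a lower number here means a stronger inhibitor, a higher number a weaker inhibitor:
compound 1 `COc1ccc(-n2nncc2CN2C(=O)C3(C(C#N)=C(N)Oc4c(N)cc5nc6ccccc6nc5c43)c3ccccc32)cc1` gives > 50000 nM, a limit of the assay.
compound 2 `N#CC1=C(N)Oc2c(N)cc3nc4ccccc4nc3c2C12C(=O)N(Cc1cnnn1-c1ccc([N+](=O)[O-])cc1)c1ccccc12` gives > 50000 nM, a limit of the assay.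
compound 3 `Cc1ccc(-n2nncc2CN2C(=O)C3(C(C#N)=C(N)Oc4c(N)cc5nc6ccccc6nc5c43)c3ccccc32)cc1C` gives > 50000 nM, a limit of the assay.

Compound 3 stands only at a limit in this assay, and the two other values are limits as well (the limit of > 50000 nM in this assay, at which 3 of the 3 values shown sit). The steps a step that the two limits leave unreadable from compound 1 to compound 2, a step that the two limits leave unreadable from compound 1 to compound 3 and a step that the two limits leave unreadable from compound 2 to compound 3 therefore carry no readable size. Compound 4 `N#CC1=C(N)Oc2c(N)cc3nc4ccccc4nc3c2C12C(=O)N(Cc1cnnn1-c1ccc(F)c(Cl)c1)c1ccccc12` differs from compound 3 by 3-chloro-4-fluorophenyl in place of 3,4-dimethylphenyl on an aromatic nitrogen. The two steps into compound 3 bear on this change, both being swaps of the group on the same aromatic nitrogen, yet neither gives a size. The step in this assay is expected to be a step that the limit leaves unreadable from compound 3 to compound 4, none beyond the scatter, with compound 4 most likely staying at the limit. Compound 4 is estimated at 60000 nM, in the range 20000 nM to 200000 nM.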

Compound 4, half-maximal inhibitory concentration: > 50000 nM
Compound 4: a limit, no number; the forecaster's own chance of this, stated with the estimate: 80%; the middle value is on the limit's open side.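

In this assay, among these compounds, compound 4 gives > 50000 nM, a limit and not a number, so no step from compound 1, compound 2 or compound 3 to compound 4 can be read. How these aryl groups on the aromatic nitrogen rank in this assay stays open, with every value shown at one limit: the limit of > 50000 nM in this assay, at which 4 of the 4 values shown sit.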